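From methyl to chloro beside the same carbonyl

This account rests on a few compounds, and the source may have more. Where it says the series, first, only, none or still open, it means among the compounds named here.

Of the compounds shown here, three of the shared core have been measured in an assay on HL-60 cells for inhibition of glutathione S-transferase P (Homo sapiens); a higher number here means a weaker inhibitor, a lower number a stronger inhibitor. Compound 1 `C=C(C)C(=O)c1ccc(OCc2nc(-c3ccc(C(F)(F)F)cc3)no2)cc1Br` gives 1300 nM. Compound 2 `C=C(C)C(=O)c1ccc(OCc2nc(-c3ccc(C(F)(F)F)cc3)no2)cc1C` gives 3300 nM, and compound 3 `C=C(C)C(=O)c1ccc(OCc2nc(-c3ccc([N+](=O)[O-])cc3)no2)cc1C` gives 2900 nM. Compound 2 stands at the highest of the three numbers: its step to compound 3 is within the scatter, while the step of a 2.5-fold higher number from compound 1 to compound 2 (0.40 log units; beyond the scatter) is beyond it. The step of a 1.1-fold lower number from compound 2 to compound 3 (0.06 log units; within the scatter) changes nothing that the scatter would not cover.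

Compound 4 `C=C(C)C(=O)c1ccc(OCc2nc(-c3ccc(C(F)(F)F)cc3)no2)cc1Cl` is not yet measured. It differs from compound 2 by chloro in place of methyl on an aromatic carbon. For the measured compounds named here, the measured step that bears on this change is the one from compound 1 to compound 2, in which a methyl in place of a bromo raised the number by a 2.5-fold higher number from compound 1 to compound 2 (0.40 log units; beyond the scatter); chloro, like bromo, is a halogen entering at the same place, so the account expects the reverse direction. Compound 4 is therefore estimated to give a lower number in this assay than compound 2, a step of about a 1.8-fold lower number from compound 2 to compound 4 (0.26 log units; within the scatter), and its value is expected near 1800 nM, within a range from 800 nM to 4000 nM.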

Compound 4, half-maximal inhibitory concentration: 700 nM
The estimate for compound 4 lay 2.6-fold (0.41 log units) above the measured number; the measured number lies below the stated range.
By their numbers in this assay, from the lowest: compounds 4 and 1 (each within the scatter of the next); then compounds 3 and 2 (each within the scatter of the next).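

In this assay the step of a 4.7-fold lower number from compound 2 to compound 4 (0.67 log units; beyond the scatter) lies beyond the scatter, so compound 4 shows that a second halogen, and not bromo alone, separates from methyl on this aromatic carbon ortho to the (1-methylethenyl)carbonyl group. The step of a 1.9-fold lower number from compound 1 to compound 4 (0.27 log units; within the scatter) stays within the scatter, so chloro and bromo cannot be told apart at this place, and among the three compounds that differ only here, the two halogen compounds both give lower numbers than the methyl compound. Nothing available explains why methyl differs from the two halogens at this position.

The compounds shown leave open whether this holds for other groups on the same aromatic carbon, such as fluoro, a methoxy group or an amine, and so whether it belongs to halogens in general or only to chloro and bromo. They also leave open whether the change from trifluoromethyl to nitro, which has been read only with methyl at this place, would stay within the scatter with chloro there.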